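The source may hold more compounds than are shown below. What is called first, only, known or untested is meant among the compounds shown, and "the series" means these compounds.

Two analogues sharing one core have been measured in an assay on HEK293 cells for agonist activity at Bile acid receptor (Homo sapiens), read by a luciferase reporter; a lower number here means a smaller maximal response, a higher number a larger maximal response. Compound 1 `CC(C)OC(=O)C1CN(C(=O)c2cccc(Cl)c2)CC(C)(C)c2cc(C#N)[nH]c21` gives 103%. Compound 2 `CC(C)OC(=O)C1=CN(C(=O)c2ccc(F)cc2)CC(C)(C)c2cc(C#N)[nH]c21` gives 119% in this assay, the higher of the two numbers, and the gap to compound 1 lies beyond the scatter. The pair differs in more than one place, so the two values are simply noted side by side without a defined step.

The next compound, compound 3 `CC(C)OC(=O)C1=CN(C(=O)c2ccc(F)c(F)c2)CC(C)(C)c2cc(C#N)[nH]c21`, has not yet been measured in this assay. Relative to compound 2 the change is fluoro in place of hydrogen on an aromatic carbon. Within the data shown here, no single-point step between measured compounds exists to calibrate a change of this kind. Any step is expected to be small, within or near the scatter, with uncertain direction: a number 4 percentage points lower from compound 2 to compound 3 (within the scatter). Compound 3 is accordingly estimated at 115% in this assay, with an expected range from 95% to 135%.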

Compound 3, largest response reached (reported as efficacy), in percent of the reference or control that the assay uses: 121%
Beside the measured number, compound 3's estimate is 6 percentage points below it; measured number inside the range.
By their numbers in this assay, from the lowest: compound 1; then compounds 2 and 3 (each within the scatter of the next).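

In this assay, among these compounds, the change from 4-fluorophenyl to 3,4-difluorophenyl on the carbonyl gives a number 2 percentage points higher from compound 2 to compound 3 (within the scatter), the first step that can be read at a single place. At this aromatic carbon, ortho to a fluoro group, fluoro can thus take the place of hydrogen while the maximal responses of the two compounds remain indistinguishable, and the step gives no direction for this change. No supporting data bear on this result, so it remains an observation of the maximal response alone.

Going by these compounds, only hydrogen and fluoro are compared at this carbon, so it remains open whether a larger or differently built group, such as methoxy, an amine or a carboxylic acid, would be tolerated in the same way. Also open, on these data alone, is whether fluoro in place of hydrogen would give a similar step on the core of compound 1.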